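A few compounds are considered here, and "the series" means these few. Any claim that something is new, unique, unknown or untested is made for them only; others in the source may bear on it.

Measured in an ADME assay on the whole organism (blood, strain Han-Wistar) for pharmacokinetics, with Rattus norvegicus as the target, read by LC-MS, at a dose of 1 mg/kg by the intravenous route; on this read-out lower numbers stand for slow clearance and higher numbers for fast clearance:
Compound 1 `Cc1ccc([C@@H](C)Oc2cc3onc(CCC(=O)O)c3cc2Cl)nc1`: 1.1 mL/min/kg
Compound 2 `O=C(O)CCn1c(=O)oc2cc(Cl)c(Cl)cc21`: 4.3 mL/min/kg

Of these two numbers, the lower belongs to compound 1 at 1.1 mL/min/kg. The higher belongs to compound 2 at 4.3 mL/min/kg, and the gap between them lies beyond the usual scatter of repeated measurements.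

Compound 3 `Cc1ccc([C@@H](C)Oc2cc3onc(CCC(=O)O)c3cc2Cl)nn1` has not yet been measured. It differs from compound 1 in one place: 6-methylpyridazin-3-yl in place of 5-methylpyridin-2-yl on a saturated chain carbon bound to an oxygen on an aromatic ring and a saturated chain carbon. In words, 6-methylpyridazin-3-yl stands in place of 5-methylpyridin-2-yl on a saturated chain carbon bound to an oxygen on an aromatic ring and a saturated chain carbon.

Within the data shown here, no measured pair shows this exchange, and compound 1 and compound 2 differ in much more than one place, so the data offer no direct guide. In this assay, a small upward step that stays within the scatter is expected, though a larger rise cannot be ruled out. Compound 1 at 1.1 mL/min/kg sits low on this scale, so a rise seems likelier than a fall. The expected change is a 1.5-fold higher number from compound 1 to compound 3 (0.16 log units; within the scatter). For compound 3, the estimated clearance is 1.6 mL/min/kg, with an expected range of 0.6 mL/min/kg to 4 mL/min/kg.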

Compound 3, clearance: 12 mL/min/kg
For compound 3 the middle estimate is 7.5-fold (0.88 log units) below the measured one; the measured number lies above the stated range.
By their numbers in this assay, from the lowest: compound 1; then compound 2; then compound 3.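

In this assay, putting 6-methylpyridazin-3-yl in place of 5-methylpyridin-2-yl gives an 11-fold higher number from compound 1 to compound 3 (1.04 log units; beyond the scatter) and so counts as a large step. This shows that the group on the saturated chain carbon is a sensitive place in this series: a single exchange here moves clearance well beyond the usual scatter, even though the rest of the molecule stays the same and both groups are six-membered aromatic rings with 7 heavy atoms, the entering one having 2 hetero atoms and 2 hydrogen-bond acceptors where the leaving one has 1 of each. Nothing measured here explains what lies behind this rise.

The compounds shown leave open whether the rise follows from having a second ring nitrogen at all or from where that nitrogen stands, a question that a pyrimidine or pyrazine ring carrying a methyl group could help to answer. They also leave open whether the methyl group plays any part, and whether the same exchange would produce a step of similar size on a different core.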